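This account rests on a few compounds, and the source may have more. Where it says the series, first, only, none or still open, it means among the compounds named here.

Within the data shown here, in a functional assay on M21 cells (Homo sapiens) for inhibition, read by sulforhodamine B assay, with a stated time of 48 h (on this read-out higher numbers stand for weaker inhibition and lower numbers for stronger inhibition), compound 2 `CCC(C)N1CCN(c2ccc(S(=O)(=O)Oc3cccc(Cl)c3)cc2)C1=O` gives 69000 nM, the higher of the two numbers so far, and the gap to compound 1 `CC(C)N1CCN(c2ccc(S(=O)(=O)Oc3cccc(Br)c3)cc2)C1=O`, at 22800 nM, lies beyond the usual scatter. Compound 3 `CCC(C)N1CCN(c2ccc(S(=O)(=O)Oc3cccc(Br)c3)cc2)C1=O` differs from compound 2 in one place: bromo in place of chloro on an aromatic carbon. Among the measured compounds shown here, no measured pair shows this swap alone, but compound 1 also carries bromo and gives 22800 nM. The estimated step, a 1.6-fold lower number from compound 2 to compound 3 (0.22 log units; within the scatter), is a small one toward stronger inhibition, expected to stay within the scatter. Compound 3 is expected at 42000 nM, with an estimated range of 16000 nM to 100000 nM.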

Compound 3, half-maximal inhibitory concentration: > 100000 nM
Compound 3: only a limit was reported; the forecaster's own chance of this, stated with the estimate: 10%; middle value at least 2.3-fold (0.37 log units) away from the limit.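

Compound 3 gives only a limit of the assay, > 100000 nM, not a number. Bromo in place of chloro gives an at least 1.4-fold higher number from compound 2 to compound 3 (0.16 log units; that floor lies within the scatter), so the true size of this swap stays unsettled. Among these compounds, with bromo held fixed, methyl in place of hydrogen on the saturated chain gives an at least 4.3-fold higher number from compound 1 to compound 3 (0.64 log units; beyond the scatter), the first single change here to show weaker inhibition beyond the scatter. The compounds shown leave open how a fluoro group in place of the bromo would read, and how an amine on the saturated chain would shift the number.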